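This account rests on a few compounds, and the source may have more. Where it says the series, first, only, none or still open, it means among the compounds named here.

In an ADME assay on HS27 cells (Homo sapiens) for cytotoxicity, read by MTT assay, with a stated time of 24 h (a lower number here means a stronger inhibitor of growth, a higher number a weaker inhibitor of growth), compound 1 `Cc1ccc(NC(=O)C2(C)CCc3c(C)c(O)c(C)c(C)c3O2)cc1NC(=O)c1cnoc1C` gives > 30000 nM, which is a limit of the assay and not a number. Compound 2 `Cc1ccc(NC(=O)Cc2c[nH]c3ccccc23)cc1NC(=O)c1cnoc1C` gives > 30000 nM, again a limit. Compound 3 `Cc1ccc(NC(=O)Nc2ccccc2F)cc1NC(=O)c1cnoc1C` gives > 30000 nM, also a limit, so it has no exact value. Compound 3 therefore shares its place with the other two, and the overall picture is the limit of > 30000 nM in this assay, at which 3 of the 3 values shown sit.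

Compound 4 `Cc1ccc(NC(=O)Nc2cc(Cl)cc(Cl)c2)cc1NC(=O)c1cnoc1C` carries 3,5-dichlorophenyl in place of 2-fluorophenyl on an amide-type nitrogen. No measured pair of these compounds differs in just one place, so no direct guide to the size of this change exists. The expectation rests on compound 3 and its limit of > 30000 nM. In this assay, no change beyond the usual scatter is expected, and if one appears, the likelier direction is towards stronger inhibition of growth. The expected step is a number no higher from compound 3 to compound 4 (the limit leaves the size open). For compound 4 the estimated value is 30000 nM, with an expected range from 12000 nM to 50000 nM.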

Compound 4, concentration for 50% growth inhibition: > 30000 nM
Compound 4 ended at the assay's limit (the forecaster's own chance of this, stated with the estimate: 70%); the middle value sits exactly at the limit.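

Compound 3 and compound 4 both end at a limit and not at a number, so no step can be read for 3,5-dichlorophenyl in place of 2-fluorophenyl. The compounds shown leave open how strongly any of them inhibits growth in this assay as all results are one limit: the limit of > 30000 nM in this assay, at which 4 of the 4 values shown sit.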